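Acyl variation at the ring nitrogen: efficacy notes

The compounds below may be only part of what the source reports. "The series", "measured", "known", "first", "only" and "open" are said of these compounds alone.

Measured compounds:
compound 1 `Cc1nc(S(C)(=O)=O)ccc1Oc1ncnc(OC2CCN(C(=O)OC3CCC3)CC2)c1F`, 81%
compound 2 `Cc1nc(S(C)(=O)=O)ccc1Oc1ncnc(OC2CCN(C(=O)OC(C)F)CC2)c1F`, 68%
compound 3 `Cc1nc(S(C)(=O)=O)ccc1Oc1ncnc(OC2CCN(C(=O)SC(C)C)CC2)c1F`, 81%

In a functional assay on isolated protein for inhibition of Glucose-dependent insulinotropic receptor (Rattus norvegicus), read by HTRF and cAMP accumulation (on this read-out lower numbers stand for smaller maximal responses and higher numbers for larger maximal responses), compound 3 gives 81%. It stands level with compound 1, as no change at the digits printed from compound 1 to compound 3 (within the scatter) shows, and the pair sits together at the top of the three numbers; the gap to compound 2 is real, a number 13 percentage points higher from compound 2 to compound 3 (beyond the scatter).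

The next compound is compound 4 `CCC(F)(F)C(=O)N1CCC(Oc2ncnc(Oc3ccc(S(C)(=O)=O)nc3C)c2F)CC1`. Relative to compound 3 the change is 1,1-difluoropropyl in place of isopropylsulfanyl on a carbonyl carbon.

Among the measured compounds shown here, two measured steps bear on this. The exchange of isopropylsulfanyl for cyclobutyloxy, no change at the digits printed from compound 1 to compound 3 (within the scatter), left the maximal response unmoved, so swapping the group on the carbonyl carbon need not move the number. For the measured compounds named here, the only step in which a fluorine-bearing group entered on that side of the molecule, a number 13 percentage points lower from compound 1 to compound 2 (beyond the scatter), lowered the response by a modest amount. Compound 4 also brings in a fluorine-bearing group, and on this thin basis a modest fall is expected, a number 7 percentage points lower from compound 3 to compound 4 (within the scatter), with a range that still admits no change. For compound 4 the expected value in this assay is 74%, estimated between 62% and 86%.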

Compound 4, largest response reached (reported as efficacy), in percent of the reference or control that the assay uses: 90%
The estimate for compound 4 lay 16 percentage points below the measured number; the whole stated range lies below it.
By their numbers in this assay, from the lowest: compound 2; then compounds 1, 3 and 4 (each within the scatter of the next).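

In this assay the step of a number 9 percentage points higher from compound 3 to compound 4 (within the scatter) and the step of a number 9 percentage points higher from compound 1 to compound 4 (within the scatter) place the 1,1-difluoropropyl amide in one band with the cyclobutyloxy and isopropylsulfanyl compounds, so this carbonyl carbon, whose other neighbour is the amide-type nitrogen in a ring, tolerates a group joined directly through carbon as well as groups joined through oxygen or sulfur. The step of a number 22 percentage points higher from compound 2 to compound 4 (beyond the scatter) shows that a fluorine-bearing group on this carbonyl carbon does not by itself go with a lower maximal response, which leaves compound 2 as the only one of the four apart from the band and as the exception to any reading of this position as indifferent to the group placed there. No measurement at hand accounts for the gap between compound 2 and compound 4.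

Still open, going by these compounds, is whether the gap follows the oxygen link or the fluorine count, a question that 1-fluoroethyl joined directly to the carbonyl carbon would address. On these data alone, how far the band extends also remains open, for instance to a longer chain such as 1,1-difluorobutyl, to trifluoromethyl or to a dimethylamino group at this place.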